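The source may hold more compounds than are shown below. What is called first, only, known or untested is meant among the compounds shown, and "the series" means these compounds.

Measured compounds so far:

Compound 1, `Cn1cc(S(=O)(=O)CC(=O)Nc2ccc(Cl)cc2Cl)c2ccccc21`, stands at a limit: in an ADME assay on HEK-293T cells (Homo sapiens) for cytotoxicity, read by CCK-8 assay, with a stated time of 48 h (on this read-out higher numbers stand for lower toxicity in this test and lower numbers for higher toxicity in this test), compound 1 gives > 100000 nM.

Compound 2, `CCOc1ccccc1NC(=O)CSc1c[nH]c2c(Cl)cccc12`, also stands at a limit: in this assay compound 2 gives > 100000 nM.

Compound 3, `COc1cccc2c(SCC(=O)Nc3ccc(Cl)c(Cl)c3)c[nH]c12`, likewise stands at a limit: in this assay compound 3 gives > 100000 nM.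

Compound 2 therefore sits where every compound shown sits, at the limit of > 100000 nM in this assay, at which 3 of the 3 values shown sit, so none of the three can be placed above or below another. The unmeasured compound 4, `CCOc1ccccc1NC(=O)CSc1c[nH]c2c(OC)cccc12`, differs from compound 2 in a single place: methoxy in place of chloro on an aromatic carbon. Among the compounds with values here, no step between two measured compounds exists, so no effect of any structural change on cytotoxicity has been observed here. The expectation for compound 4 rests on the shared reading: because all three measured values sit at the limit of > 100000 nM in this assay, at which 3 of the 3 values shown sit, the change in this assay is expected to be none beyond the scatter. The step that the limit leaves unreadable from compound 2 to compound 4 is estimated to be flat. Compound 4 is expected to give 150000 nM, with a range from 60000 nM to 400000 nM, most likely reported again only as a limit.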

Compound 4, half-maximal cytotoxic concentration: > 100000 nM
Compound 4 ended at the assay's limit (the forecaster's own chance of this, stated with the estimate: 85%); the middle value lies beyond the limit too.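

No step can be read between compound 2 and compound 4, since both end at a limit in this assay and not at a number: the limit of > 100000 nM in this assay, at which 4 of the 4 values shown sit. The compounds shown leave open at what concentration any of them would become toxic to these cells, and whether methoxy in place of chloro on an aromatic carbon alters that concentration.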